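Changing the para group on the aryl ring: estimating compound 4

The compounds below may be only part of what the source reports. "The series", "measured", "known", "first", "only" and "open" are said of these compounds alone.

Measured so far:
compound 1 `CCCS(=O)(=O)Nc1ccc(F)c(C(=O)c2n[nH]c3ncc(-c4ccc(S(N)(=O)=O)cc4)cc23)c1F`, 5.1%
compound 2 `CCCS(=O)(=O)Nc1ccc(F)c(C(=O)c2n[nH]c3ncc(-c4ccc(S(=O)(=O)NC(C)=O)cc4)cc23)c1F`, 0.5%
compound 3 `CCCS(=O)(=O)Nc1ccc(F)c(C(=O)c2n[nH]c3ncc(-c4ccc(NS(C)(=O)=O)cc4)cc23)c1F`, 16%

In an assay for binding affinity to dual specificity mitogen-activated protein kinase kinase 4 (Homo sapiens), read by KINOMEscan, tested at 10 nM (on this read-out higher numbers stand for a weaker effect at the one concentration tested and lower numbers for a stronger effect), compound 3 gives the highest of the three numbers, that is the weakest binding; the steps of a number 10.9 percentage points higher from compound 1 to compound 3 (beyond the scatter) and a number 15.5 percentage points higher from compound 2 to compound 3 (beyond the scatter) both lie beyond the scatter, while a number 4.6 percentage points lower from compound 1 to compound 2 (within the scatter) does not. Compound 4 `CCCS(=O)(=O)Nc1ccc(F)c(C(=O)c2n[nH]c3ncc(-c4ccc(C(=O)O)cc4)cc23)c1F` carries the change (carboxy in place of methanesulfonamido on an aromatic carbon). The two steps into compound 3 show that swapping the group on this aromatic carbon can move the read-out by a modest amount, so a step away from methanesulfonamido is expected to lower the number, though a carboxy group has not been tested here. The estimated step is a number 7 percentage points lower from compound 3 to compound 4 (within the scatter), and compound 4 is therefore expected to read about 9%, within roughly 2% to 28%.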

Compound 4, a percentage reported as activity, at one concentration (the size of the read-out at that concentration, not a potency): 0.2%
For compound 4 the middle estimate is 8.8 percentage points above the measured one, outside the stated range (below it).
By their numbers in this assay, from the lowest: compounds 4, 2 and 1 (each within the scatter of the next); then compound 3.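

In this assay, carboxy on this aromatic carbon gives a number 15.8 percentage points lower from compound 3 to compound 4 (beyond the scatter) and so shows that a group without sulfur can replace methanesulfonamido here and give a low number. The changes giving a number 4.9 percentage points lower from compound 1 to compound 4 (within the scatter) and a number 0.3 percentage points lower from compound 2 to compound 4 (within the scatter) leave carboxy not separable from sulfamoyl or acetylsulfamoyl, so methanesulfonamido alone stands apart among these four groups. Nothing available explains this difference. Open, from the compounds shown here alone, is whether a primary carboxamide or a methyl ester in the same place would match carboxy. Going by these compounds, an aminomethyl group there also remains open.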